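The compounds below may be only part of what the source reports. "The series", "measured", "known", "first", "only" and "open" are said of these compounds alone.

Compound 3 `CN(CCN1CCCCC1)c1ccc(Cn2c(=O)[nH]c3c(N)nc(C(F)(F)F)cc32)cn1` gives 25 mL.min-1.g-1 in an in vitro ADME assay on microsomes from liver (Homo sapiens) for pharmacokinetics; on this read-out higher numbers stand for fast clearance and lower numbers for slow clearance. Of the two plain numbers reported, its reading is the larger, but its nearest neighbour, compound 1 `Nc1nc(C(F)(F)F)cc2c1[nH]c(=O)n2Cc1ccc(NCCN2CCCCC2)nc1`, gives 13 mL.min-1.g-1 in this assay, and the difference a 1.9-fold higher number from compound 1 to compound 3 (0.28 log units; within the scatter) stays within the scatter. Compound 2 `Nc1nc(C(F)(F)F)cc2c1[nH]c(=O)n2Cc1ccc(NCc2ccccc2)nc1` gives < 8 mL.min-1.g-1 in this assay, which is a limit of the assay rather than a number, (the limit of < 8 mL.min-1.g-1 in this assay, at which 1 of the 3 values shown sits). Compound 1 and compound 2 are separated by an at least 1.6-fold lower number from compound 1 to compound 2 (0.21 log units; that floor lies within the scatter), whereas an at least 3.1-fold higher number from compound 2 to compound 3 (0.49 log units; beyond the scatter) is the only step among these three that goes beyond the scatter.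

Compound 4 `CCN(CC)CCN(C)c1ccc(Cn2c(=O)[nH]c3c(N)nc(C(F)(F)F)cc32)cn1` has not yet been measured. It differs from compound 3 by diethylamino in place of piperidin-1-yl on a saturated chain carbon, two bonds along the chain from a nitrogen on an aromatic ring. Going by the values given here, none of the measured steps alters the amine in this way; the closest is the exchange of the whole (piperidin-1-yl)methyl for phenyl in an at least 1.6-fold lower number from compound 1 to compound 2 (0.21 log units; that floor lies within the scatter), whose floor lies within the scatter. Trading one saturated amine for another is therefore expected to give no step beyond the scatter in this assay, no change at the digits printed from compound 3 to compound 4 (within the scatter). Compound 4 is estimated at 25 mL.min-1.g-1, with a range from 12 mL.min-1.g-1 to 50 mL.min-1.g-1.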

Compound 4, intrinsic clearance in microsomes: 24 mL.min-1.g-1
Compound 4: middle estimate off by 1.0-fold (0.02 log units), on the high side; the range from low to high includes it.
By their numbers in this assay, from the lowest: compounds 1, 4 and 3 (each within the scatter of the next). At a limit, below all of these: compound 2.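

In this assay, the first change shown at the amine itself, diethylamino in place of piperidin-1-yl, gives a 1.0-fold lower number from compound 3 to compound 4 (0.02 log units; within the scatter), so at this place on the saturated chain carbon, two bonds along the chain from a nitrogen on an aromatic ring, a group with no ring takes the place of the six-membered ring without a step beyond the scatter. Going by these compounds alone, compound 4 also stands much as compound 3 does towards the other two compounds, with a 1.8-fold higher number from compound 1 to compound 4 (0.27 log units; within the scatter) and, the only one of the new steps that goes beyond the scatter, an at least 3.0-fold higher number from compound 2 to compound 4 (0.47 log units; beyond the scatter). That last step has only a floor, as compound 2 gives a limit of the assay and not a number: the limit of < 8 mL.min-1.g-1 in this assay, at which 1 of the 4 values shown sits.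

From the compounds shown here alone, whether the reading stays the same with other amines at this place, such as morpholine or a piperazine, or with a longer chain in place of the ethyl link, remains open. The step from compound 2 exchanges the whole group at once, so it does not tell which part of that group goes with the higher number.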